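The source may hold more compounds than are shown below. What is called first, only, known or untested is meant among the compounds shown, and "the series" means these compounds.

Of the compounds shown here, three have so far been measured in a functional assay on A-375 cells (Homo sapiens) for cytotoxicity, read by MTT assay, with a stated time of 72 h, tested at 3 uM; on this read-out lower numbers stand for less inhibition of growth and higher numbers for more inhibition of growth at the one concentration tested. Compound 1 `N/C(=N\NC(=S)N1CCCCCC1)c1ccccn1` gives 78.6%, and compound 2 `N/C(=N\NC(=S)N1CCSCC1)c1ccccn1` gives 80%; these two numbers lie within the scatter of each other, and the difference between the two cores is not broken down here. Compound 3 `N/C(=N\NC(=S)N1CCSCC1)c1ccc(F)cn1` gives 62.2%. Among the measured compounds shown here, the only change from compound 2 to compound 3 is fluoro in place of hydrogen on an aromatic carbon and it produced a number 17.8 percentage points lower from compound 2 to compound 3 (beyond the scatter).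

Compound 4 `N/C(=N\NC(=S)N1CCCCCC1)c1ccc(F)cn1` is not yet measured. For the measured compounds named here, it differs from compound 1 by fluoro in place of hydrogen on an aromatic carbon, which is the same change as the one made from compound 2 to compound 3, made on the core of compound 1 instead. Because that earlier step gave a number 17.8 percentage points lower from compound 2 to compound 3 (beyond the scatter), a step of similar size is expected here, that is a number 17.6 percentage points lower from compound 1 to compound 4 (beyond the scatter). On that basis compound 4 is estimated to give about 61% in this assay, most likely somewhere between 48% and 73%.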

Compound 4, percent growth inhibition at one concentration: 66.6%
Compound 4: middle estimate off by 5.6 percentage points, on the low side, and the stated range covers the measured number.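

On the core of compound 1, fluoro in place of hydrogen on an aromatic carbon gives a number 12 percentage points lower from compound 1 to compound 4 (beyond the scatter), so the fall in growth inhibition seen on the other core appears here too. The two steps run in the same direction and cannot be told apart in size: the same change on two cores in this assay, a number 17.8 percentage points lower (beyond the scatter) from compound 2 to compound 3 and a number 12 percentage points lower (beyond the scatter) from compound 1 to compound 4, 5.8 percentage points apart, within the scatter of two such steps. Among the compounds shown here, this rests on only two cores and one place on the ring, so it does not show that the change would carry over in the same way to any other core.

The compounds shown leave open whether another group at the same place, such as chloro, methoxy or an amine, would give a similar step. They also leave open what fluoro would do on a different carbon of the ring.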